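Aryl amide variation on the shared core: outlook for compound 4

This account rests on a few compounds, and the source may have more. Where it says the series, first, only, none or still open, it means among the compounds named here.

Measured in a functional assay on WI-38 VA13 cells (Homo sapiens) for cytotoxicity; a lower number here means that less compound is needed, a higher number that more compound is needed for the effect:
compound 1 `O=C(Nc1ccc2nc(NC(=O)C3CCCCC3)sc2c1)c1ccccc1Cl` gives 0.025 ug/mL
compound 2 `O=C(Nc1ccc2nc(NC(=O)C3CCCCC3)sc2c1)c1cccc(F)c1` gives 0.64 ug/mL
compound 3 `COc1ccc(C(=O)Nc2ccc3nc(NC(=O)C4CCCCC4)sc3c2)cc1` gives 4.9 ug/mL

Compound 1 stands lowest of the three in this assay. The steps away from it are a 26-fold higher number from compound 1 to compound 2 (1.41 log units; beyond the scatter) and a 200-fold higher number from compound 1 to compound 3 (2.29 log units; beyond the scatter), while between the other two a 7.7-fold higher number from compound 2 to compound 3 (0.88 log units; beyond the scatter). Compound 4 `O=C(Nc1ccc2nc(NC(=O)C3CCCCC3)sc2c1)c1ccc(Cl)cc1Cl` differs from compound 1 by chloro in place of hydrogen on an aromatic carbon. Going by the values given here, no measured step adds a group while keeping the 2-chlorophenyl; the two steps from compound 1 show only that exchanging the 2-chlorophenyl amide for another aryl amide raises the number strongly. The 2-chloro group is retained in compound 4, so for compound 4 the expected step is a 1.6-fold higher number from compound 1 to compound 4 (0.20 log units; within the scatter), within or near the scatter, direction uncertain. Compound 4 is estimated at 0.04 ug/mL, range 0.01 ug/mL to 0.2 ug/mL.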

Compound 4, half-maximal effective concentration: > 4 ug/mL
Compound 4: a limit, no number; the forecaster's own chance of this, stated with the estimate: 5%; middle value at least 100-fold (2.00 log units) away from the limit.
By their numbers in this assay, from the lowest: compound 1; then compound 2; then compound 3.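

In this assay compound 4 carries a limit and not a number: the limit of > 4 ug/mL in this assay, at which 1 of the 4 values shown sits.

Chloro in place of hydrogen, para to a large group, gives an at least 160-fold higher number from compound 1 to compound 4 (2.20 log units; beyond the scatter), so retaining the 2-chloro group does not alone keep the number low. The 2,4-dichlorophenyl amide also gives an at least 6.2-fold higher number from compound 2 to compound 4 (0.79 log units; beyond the scatter), while the step from compound 3 cannot be read against the limit.

Open, on these data alone, is whether the rise is specific to chloro or follows any group at this position. An amine or a carboxylic acid there, with the 2-chloro group retained, would separate these readings.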